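This account rests on a few compounds, and the source may have more. Where it says the series, first, only, none or still open, it means among the compounds named here.

Compound 1 `CCCCCCCCc1ccc(CCC(CO)(CO)NC(C)=O)c2ccccc12` — 36500 nM
Compound 2 `CCCCCCCCc1ccc(CCC(CO)(CO)NC(=O)CCCCC)c2ccccc12` — 20300 nM
Compound 3 `CCCCCCCOc1ccc(CCC(CO)(CO)NC(C)=O)c2ccccc12` — 17600 nM

All three were tested in a functional assay on HT-29 cells (Homo sapiens) for antiproliferative activity, read by sulforhodamine B assay, with a stated time of 72 h; a lower number here means a stronger inhibitor, a higher number a weaker inhibitor. Compound 2 is compound 1 with one change, (butyl in place of hydrogen on a saturated chain carbon bound to a carbonyl carbon), and that change gave a step of a 1.8-fold lower number from compound 1 to compound 2 (0.25 log units; within the scatter). Compound 3 shares the two-hydroxymethyl, acetamido-bearing side chain of compound 1 but its core differs: heptyloxy in place of octyl on an aromatic carbon. That change gave a step of a 2.1-fold lower number from compound 1 to compound 3 (0.32 log units; beyond the scatter). For the measured compounds named here, compound 2 and compound 3 differ at two places and no single step is counted between them; their values sit close together.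

Compound 4 `CCCCCCCOc1ccc(CCC(CO)(CO)NC(=O)CCCCC)c2ccccc12` has not yet been measured in this assay. It stands to compound 3 as compound 2 stands to compound 1: butyl in place of hydrogen on a saturated chain carbon bound to a carbonyl carbon. The place of the change is described in the same words in both pairs, so this is the same change made on a different core.

Compound 4 is expected to sit a little lower than compound 3, the step being estimated at a 1.6-fold lower number from compound 3 to compound 4 (0.20 log units; within the scatter), because the same change gave a 1.8-fold lower number from compound 1 to compound 2 (0.25 log units; within the scatter). Compound 4 is therefore estimated at about 11000 nM, with a range from 5500 nM to 22000 nM.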

Compound 4, half-maximal inhibitory concentration: 21900 nM
Beside the measured number, compound 4's estimate is 2.0-fold (0.30 log units) below it; measured number inside the range.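

In this assay, butyl in place of hydrogen on a saturated chain carbon bound to a carbonyl carbon gave a 1.2-fold higher number from compound 3 to compound 4 (0.09 log units; within the scatter), and heptyloxy in place of octyl on an aromatic carbon gave a 1.1-fold higher number from compound 2 to compound 4 (0.03 log units; within the scatter). The butyl change cannot be said to act differently on the two cores, but steps this small do not prove that its effect carries over unchanged: the same change on two cores in this assay, a 1.8-fold lower number (0.25 log units; within the scatter) from compound 1 to compound 2 and a 1.2-fold higher number (0.09 log units; within the scatter) from compound 3 to compound 4, 2.2-fold (0.35 log units) apart, within the scatter of two such steps. The heptyloxy change reads the same way, even though only its first step lay beyond the scatter: the same change on two cores in this assay, a 2.1-fold lower number (0.32 log units; beyond the scatter) from compound 1 to compound 3 and a 1.1-fold higher number (0.03 log units; within the scatter) from compound 2 to compound 4, 2.2-fold (0.35 log units) apart, within the scatter of two such steps.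

The compounds shown leave open whether an amine or a carboxylic acid at the end of the amide chain, or a much longer chain on the aromatic carbon, would give a step beyond the scatter. From the compounds shown here alone, all four compounds carry the same two hydroxymethyl groups, so what replacing either of them would do also remains open.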